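Aryl swap at the chain carbon: estimate for compound 4

The source may report more compounds than this note shows. Statements on the series, on what has been measured and on what is new or still open speak of the compounds shown alone.

Measured in a functional assay on SJ-G2 cells (Homo sapiens) for inhibition, read by MTT assay, with a stated time of 72 h; a higher number here means a weaker inhibitor of growth, a lower number a stronger inhibitor of growth:
- Compound 1 `COc1ccc(CNC(=O)/C(C#N)=C/c2ccc[nH]2)cc1` gives > 50000 nM, which is a limit of the assay.
- Compound 2 `COc1ccc(CNC(=O)/C(C#N)=C/c2ccc(Cl)o2)cc1` gives 13000 nM.
- Compound 3 `COc1ccc(CNC(=O)/C(C#N)=C/c2ccoc2)cc1` gives 8000 nM.

Compound 3 holds the lowest of the two numbers reported; compound 2 sits close to it, and a 1.6-fold lower number from compound 2 to compound 3 (0.21 log units; within the scatter) lies within the scatter, so the two are not separable. Compound 1 reports only a limit (the limit of > 50000 nM in this assay, at which 1 of the 3 values shown sits). Against that limit, an at least 3.8-fold lower number from compound 1 to compound 2 (0.58 log units; beyond the scatter) and an at least 6.2-fold lower number from compound 1 to compound 3 (0.79 log units; beyond the scatter) are both at least modest, each replacing 1H-pyrrol-2-yl with a furan-type ring on the double-bonded chain carbon.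

Compound 4 `COc1ccc(CNC(=O)/C(C#N)=C/c2ccc(C)cc2)cc1` is the unmeasured member: 4-methylphenyl in place of furan-3-yl on a double-bonded chain carbon bound to a double-bonded chain carbon. Within the data shown here, no measured step exchanges a five-membered ring for a six-membered ring of carbon only. Among the measured compounds shown here, the one step between two numbers, a 1.6-fold lower number from compound 2 to compound 3 (0.21 log units; within the scatter), shows the ring at that position being changed with little effect in this assay; the steps from compound 1 concern a limit and give no direction for this change. The expectation is therefore no step beyond the scatter, no change at the digits printed from compound 3 to compound 4 (within the scatter). Compound 4 is estimated at 8000 nM, range 2500 nM to 25000 nM.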

Compound 4, concentration for 50% growth inhibition: 39000 nM
For compound 4 the middle estimate is 4.9-fold (0.69 log units) below the measured one; the whole stated range lies below it.
By their numbers in this assay, from the lowest: compounds 3 and 2 (each within the scatter of the next); then compound 4. At a limit, above all of these: compound 1.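

In this assay, the ring on the double-bonded chain carbon does matter once it is a six-membered aromatic ring of carbon only, which the two furans alone could not show: 4-methylphenyl in place of furan-3-yl gives a 4.9-fold higher number from compound 3 to compound 4 (0.69 log units; beyond the scatter), and in place of 5-chlorofuran-2-yl gives a 3.0-fold higher number from compound 2 to compound 4 (0.48 log units; beyond the scatter). Both steps lie beyond the scatter and point the same way, so among the three compounds with numbers, the two furans stand lower than 4-methylphenyl. Compound 1 is reported only as a limit: the limit of > 50000 nM in this assay, at which 1 of the 4 values shown sits. Against that limit, 4-methylphenyl in place of 1H-pyrrol-2-yl gives an at least 1.2-fold lower number from compound 1 to compound 4 (0.10 log units; that floor lies within the scatter), which cannot settle how far the two differ.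

The compounds shown leave open whether the higher number goes with the six-membered ring or with its methyl. Phenyl without the methyl and a pyridine ring would help separate the two.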